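A few compounds are considered here, and "the series" means these few. Any claim that something is new, unique, unknown or untested is made for them only; others in the source may bear on it.

In an ADME assay on THP-1 cells (Homo sapiens) for cytotoxicity, read by MTT assay, with a stated time of 72 h (a higher number here means a weaker inhibitor, a lower number a stronger inhibitor), compound 1 `COc1cccc(/C=C/C(=O)c2c(O)c3ccccc3[nH]c2=O)c1` gives 38500 nM. From the compounds shown here alone, compound 2 `O=C(/C=C/C=C/c1ccccc1)c1c(O)c2ccccc2[nH]c1=O` gives > 50000 nM, which is a limit of the assay and not a number, so its true position is unknown. Compound 3 `CC(/C=C/C(=O)c1c(O)c2ccccc2[nH]c1=O)=C\c1ccccc1` is still unmeasured. The change from compound 2 is methyl in place of hydrogen on a double-bonded chain carbon bound to two double-bonded chain carbons, with methyl in place of hydrogen on a double-bonded chain carbon bound to two double-bonded chain carbons.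

Within the data shown here, only one measured step bears on this: an at least 1.2-fold higher number from compound 1 to compound 2 (0.11 log units; that floor lies within the scatter). It concerns a different change on the chain, and its floor lies within the scatter, so it offers no size to carry over. Among the measured compounds shown here, no measured step covers this methyl change. Given the step shown from compound 1 to compound 2, no step beyond the scatter is expected in this assay, and a further report at the limit remains quite possible. The expected step is a number no higher from compound 2 to compound 3 (the limit leaves the size open). For compound 3 the estimated value is 50000 nM, with an expected range of 22000 nM to 100000 nM.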

Compound 3, half-maximal inhibitory concentration: > 50000 nM
Compound 3 gave a limit, no number; the forecaster's own chance of this, stated with the estimate: 55%; the middle value lies on the limit itself.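

Compound 2 and compound 3 both report at a limit and not as numbers, so no step can be read for the methyl in place of hydrogen: the limit of > 50000 nM in this assay, at which 2 of the 3 values shown sit.

Still open, from the compounds shown here alone, are where the true values of compound 2 and compound 3 lie, and whether this methyl changes the number at all.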